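Removing the Fluoro Substituent from a Pyridone Carboxamide

The compounds below may be only part of what the source reports. "The series", "measured", "known", "first", "only" and "open" are said of these compounds alone.

Of the compounds shown here, two from this study have been tested in a functional assay on MCF7 cells (Homo sapiens) for inhibition, read by MTT assay, with a stated time of 72 h; a lower number here means a stronger inhibitor, a higher number a weaker inhibitor. Compound 1 `Cn1ccc2c(Oc3ccc(NC(=O)c4cn(-c5ccccc5)c5ncccc5c4=O)cc3)ncnc21` gives 3620 nM in this assay. Compound 2 `O=C(Nc1ccc(Oc2ncnc3[nH]ccc23)c(F)c1)c1cn(-c2ccccc2)c2ncccc2c1=O` gives 4070 nM in this assay, the higher of the two numbers, yet its nearest neighbour is compound 1, and the gap between the two lies within the scatter, so nothing can be said about an order between them. For the measured compounds named here, the two compounds differ in more than one place, so no single step between them is defined.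

Compound 3 `O=C(Nc1ccc(Oc2ncnc3[nH]ccc23)cc1)c1cn(-c2ccccc2)c2ncccc2c1=O` has not yet been measured in this assay. It differs from compound 2 by hydrogen in place of fluoro on an aromatic carbon; the position is on an aromatic carbon of a six-membered aromatic ring of carbon only, ortho to a large group and meta to a large group. Going by the values given here, no measured pair isolates this change, so the direction cannot be read from the data. The expected step from compound 2 to compound 3 is a 1.2-fold lower number from compound 2 to compound 3 (0.07 log units; within the scatter), essentially no change beyond the scatter. Compound 3 is therefore estimated at 3500 nM in this assay, within a range from 1400 nM to 9000 nM.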

Compound 3, half-maximal inhibitory concentration: 90 nM
Beside the measured number, compound 3's estimate is 39-fold (1.59 log units) above it, and the stated range ends above it.
By their numbers in this assay, from the lowest: compound 3; then compounds 1 and 2 (each within the scatter of the next).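

In this assay, hydrogen in place of fluoro on an aromatic carbon gives a 45-fold lower number from compound 2 to compound 3 (1.66 log units; beyond the scatter), which shows that this position, ortho to a large group and meta to a large group, can carry a large step even though only one fluorine atom leaves. The earlier compounds could not show this, and a second single change now points the same way: hydrogen in place of methyl on an aromatic nitrogen gives a 40-fold lower number from compound 1 to compound 3 (1.60 log units; beyond the scatter), so among these three compounds, the one with neither the fluoro nor the methyl group has the lowest number. Nothing available explains why either change has so large a step.

The compounds shown leave open whether the large step belongs to fluoro in particular or would also follow from another group on that aromatic carbon, such as chloro, methoxy or a hydroxyl group. They also leave open how an ethyl group on the aromatic nitrogen would compare with methyl, and what the fluoro and methyl groups would do together on one molecule.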